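The source may hold more compounds than are shown below. What is called first, only, known or untested is meant among the compounds shown, and "the series" means these compounds.

Measured in a functional assay on NCI-H1975 cells (Homo sapiens) for cytotoxicity, read by MTT assay, with a stated time of 72 h; on this read-out lower numbers stand for stronger inhibition and higher numbers for weaker inhibition:
Compound 1 `O=C(N/N=C/c1ccc(Br)cc1)N1CCc2ncnc(Nc3ccc(F)c(Cl)c3)c2C1`: > 200000 nM (a limit, not a number)
Compound 2 `O=C(N/N=C/c1ccc(F)cc1Cl)N1CCc2ncnc(Nc3cccc(Br)c3)c2C1`: 15700 nM
Compound 3 `O=C(N/N=C/c1ccccc1)N1CCc2ncnc(Nc3cccc(Br)c3)c2C1`: 37800 nM

Of the two true numbers, compound 3 has the higher, 37800 nM, and its nearest neighbour is compound 2 at 15700 nM. Compound 1 reports only a limit, > 200000 nM.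

Compound 4 `O=C(N/N=C/c1ccc(Br)cc1)N1CCc2ncnc(Nc3cccc(Br)c3)c2C1` is not yet measured. It is compound 3 with bromo in place of hydrogen on an aromatic carbon, para to a large group, so phenyl becomes 4-bromophenyl: bromo in place of hydrogen on an aromatic carbon.

Within the data shown here, only one measured step touches this group: a 2.4-fold higher number from compound 2 to compound 3 (0.38 log units; beyond the scatter), with phenyl in place of 2-chloro-4-fluorophenyl. That step is modest, and read in reverse it gives the substituted ring the lower number, though this rests on a single pair. Compound 1 also carries 4-bromophenyl but differs elsewhere, and its value of > 200000 nM is a limit, so the upper end of the range is kept wide.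

A small move toward a lower number is therefore expected, and the expected step is a 1.5-fold lower number from compound 3 to compound 4 (0.16 log units; within the scatter). Compound 4 is estimated at 26000 nM, with an expected range from 8000 nM to 90000 nM.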

Compound 4, half-maximal inhibitory concentration: 51000 nM
Compound 4: the middle estimate sits 2.0-fold (0.29 log units) below what was measured; the range from low to high includes it.
By their numbers in this assay, from the lowest: compound 2; then compounds 3 and 4 (each within the scatter of the next). At a limit, above all of these: compound 1.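

In this assay, bromo on the aromatic carbon para to a large group gives no change that can be told from the scatter, a 1.3-fold higher number from compound 3 to compound 4 (0.13 log units; within the scatter), whereas the 2-chloro-4-fluorophenyl ring keeps a clear edge over 4-bromophenyl, a 3.2-fold higher number from compound 2 to compound 4 (0.51 log units; beyond the scatter), so compound 4 goes against the earlier hint that a substituted ring on this side brings a lower number. The ring on the other side of the shared core now shows a step beyond the scatter, an at least 3.9-fold lower number from compound 1 to compound 4 (0.59 log units; beyond the scatter), with 3-bromophenyl in place of 3-chloro-4-fluorophenyl on a nitrogen on an aromatic ring, and this holds even though the two compounds also carry the same 4-bromophenyl group. Compound 1 reports only a limit, not a number: the limit of > 200000 nM in this assay, at which 1 of the 4 values shown sits.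

It remains open whether the chloro or the fluoro of the 2-chloro-4-fluorophenyl ring accounts for the lower number of compound 2, as neither appears alone in the compounds shown. Also open, on these data alone, is how a methoxy group, an amine or a carboxylic acid in place of bromo on that aromatic carbon would read in this assay.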